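The source may hold more compounds than are shown below. What is called first, only, known or untested is meant among the compounds shown, and "the series" means these compounds.

In a functional assay on LoVo cells (Homo sapiens) for antiproliferative activity, read by sulforhodamine B assay, with a stated time of 72 h (a lower number here means a stronger inhibitor, a higher number a weaker inhibitor), compound 1 `CC(=O)N[C@@H](CSC(=S)NCCCNC(=S)SC[C@H](NC(C)=O)C(=O)O)C(=O)O` gives 4220 nM, a measured number that shows activity in the low micromolar region. Compound 2 `CC(=O)N[C@@H](CSC(=S)Nc1cccc(NC(=S)SC[C@H](NC(C)=O)C(=O)O)c1)C(=O)O` gives no such number, and its reading is a limit, > 25000 nM. That places compound 2 at the weak end of the two results so far, at the edge of what this assay reports.

Compound 3 `CC(=O)N[C@@H](CSC(=S)Nc1ccc(C)c(NC(=S)SC[C@H](NC(C)=O)C(=O)O)c1)C(=O)O` differs from compound 2 in one place: methyl in place of hydrogen on an aromatic carbon. For the measured compounds named here, no pair measured so far shows what such a change does, so there is no direct guide to its size or direction.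

The change is small, so compound 3 is expected to stay close to the limit of compound 2, > 25000 nM. The expected step is an at least 1.2-fold lower number from compound 2 to compound 3 (0.09 log units; that floor lies within the scatter), which means no change beyond the usual scatter, and another limit is quite possible. Compound 3 is estimated at 20000 nM, with an expected range from 6000 nM to 50000 nM.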

Compound 3, half-maximal inhibitory concentration: 20500 nM
Estimate against measurement, compound 3: 1.0-fold (0.01 log units) below; measured number inside the range.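

In this assay compound 3 gives a measured number, 20500 nM, so methyl on this aromatic carbon, ortho to a large group and para to a large group, yields a reading that can be placed on the scale of the assay. The reading of compound 2, > 25000 nM, is a limit and not a number. The step can therefore be given only as a floor, an at least 1.2-fold lower number from compound 2 to compound 3 (0.08 log units; that floor lies within the scatter), so methyl here is neither shown to matter beyond the usual scatter nor ruled out as a larger gain, because one end of the step is open: the limit of > 25000 nM in this assay, at which 1 of the 3 values shown sits.

The compounds shown leave open whether a different group on this same aromatic carbon, such as a chlorine atom, a methoxy group or an amine, would move the reading further from the limit. They also leave open whether methyl acts the same way on the other carbons of the six-membered aromatic ring, where it would stand in a different relation to the two large groups.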